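This account rests on a few compounds, and the source may have more. Where it says the series, first, only, none or still open, it means among the compounds named here.

In a functional assay on SW-620 cells (Homo sapiens) for inhibition, read by MTT assay, with a stated time of 72 h (a lower number here means a stronger inhibitor of growth, a higher number a weaker inhibitor of growth), compound 1 `Cc1cc(CN2CCN(c3c(Cl)cnc4[nH]c(-c5cnn(C)c5)nc34)CC2)no1` gives 1800 nM. Within the data shown here, that is the middle of the three numbers measured so far: compound 2 `Cc1cc(CN2CCN(c3c(Cl)cnc4[nH]c(-c5ccc(N6CCN[C@@H](C)C6)cc5)nc34)CC2)no1` gives 160 nM and compound 3 `Cc1cc(CN2CCN(c3c(Br)cnc4[nH]c(-c5csnn5)nc34)CC2)no1` gives 20000 nM, and both gaps to compound 1 lie beyond the usual scatter. Neither of these two differs from compound 1 in just one place, so no clean single-change comparison is available yet.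

Compound 4 `Cc1cc(CN2CCN(c3c(Cl)cnc4[nH]c(-c5cc(C)on5)nc34)CC2)no1` differs from compound 1 in one place, with 5-methyl-1,2-oxazol-3-yl in place of 1-methyl-1H-pyrazol-4-yl on an aromatic carbon. The incoming and outgoing groups match closely in the counts, which argues against a very large change. Among the measured compounds shown here, the only other guide is weak, since it also differs elsewhere: compound 3, which carries a five-membered aromatic ring at this place too, gives 20000 nM. A moderate loss of growth inhibition therefore seems likely, and the expected step is a 2.8-fold higher number from compound 1 to compound 4 (0.44 log units; beyond the scatter). For compound 4 the estimated value is 5000 nM, with an expected range of 1500 nM to 16000 nM.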

Compound 4, concentration for 50% growth inhibition: 1150 nM
Estimate against measurement, compound 4: 4.3-fold (0.64 log units) above; the measured number lies below the stated range.
By their numbers in this assay, from the lowest: compound 2; then compounds 4 and 1 (each within the scatter of the next); then compound 3.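

At this place, on an aromatic carbon between two ring nitrogen atoms, 5-methyl-1,2-oxazol-3-yl and 1-methyl-1H-pyrazol-4-yl cannot be told apart in this assay: the exchange gives a 1.6-fold lower number from compound 1 to compound 4 (0.19 log units; within the scatter). Among these compounds, this is the first single-change comparison available, and it shows that one five-membered aromatic ring with 2 hetero atoms can replace another with the same counts while growth inhibition stays within the usual scatter. Nothing measured here accounts for this result.

One exchange cannot show how far this tolerance extends. On these data alone, it stays open how a carboxylic acid or a longer chain ending in an amine would fare at this place, and whether the same exchange would read alike if the chlorine on the core were replaced.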